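The source may report more compounds than this note shows. Statements on the series, on what has been measured and on what is new or still open speak of the compounds shown alone.

Compound 1 `C=CCc1cc(C(C)=O)c(O)cc1OCCCCC#N`: 57%
Compound 2 `C=CCc1cc(C(C)=O)c(O)cc1OCCCCCCCC#N`: 52%
Compound 3 `CCc1cc(C(C)=O)c(O)cc1OCCCCCCCC(C)(C)C#N`: 29%

Of the compounds shown here, three sharing one core have been tested in an assay on isolated protein for binding affinity to leukotriene B4 receptor 1 (Homo sapiens), tested at 1 uM; a lower number here means less inhibition, a higher number more inhibition at the concentration tested (going by the name of the read-out). Compound 3 stands lowest of the three; its gaps to compound 2 and to compound 1 both lie beyond the usual scatter, so compound 3 gives the lowest number of the measured set. The new compound, compound 4 `CCc1cc(C(C)=O)c(O)cc1OCCCCCCS(C)(=O)=O`, differs from compound 3 in one place: methylsulfonyl in place of 2-cyano-2-methylpropyl on a saturated chain carbon, six bonds along the chain from an oxygen on an aromatic ring. Within the data shown here, only one measured step touches the far end of this chain: a number 5 percentage points lower from compound 1 to compound 2 (within the scatter), a change within the scatter, which suggests that lengthening or rearranging the chain end near the nitrile moves this assay little. Among the measured compounds shown here, no measured step exchanges a nitrile for a methylsulfonyl group, so the direction of that exchange is unknown from the data. The step of a number 1 percentage points higher from compound 3 to compound 4 (within the scatter) is therefore expected to stay within the scatter, with no clear direction. Compound 4 is estimated to give 30%, within a range from 10% to 50%.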

Compound 4, a percentage reported as inhibition, at one concentration (the size of the read-out at that concentration, not a potency): 62%
For compound 4 the middle estimate is 32 percentage points below the measured one; measured number above the stated range.
By their numbers in this assay, from the lowest: compound 3; then compounds 2, 1 and 4 (each within the scatter of the next).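

In this assay, the end of this chain turns out to matter: replacing 2-cyano-2-methylpropyl with methylsulfonyl gives a number 33 percentage points higher from compound 3 to compound 4 (beyond the scatter). Among these compounds, the only earlier step at a chain end, a number 5 percentage points lower from compound 1 to compound 2 (within the scatter), showed no change beyond the scatter, so this is the first sign that the number responds to what sits on a saturated chain carbon, six bonds along the chain from an oxygen on an aromatic ring. Nothing available explains the rise.

Going by these compounds, the swap replaces a group of 6 heavy atoms with one of 4, so it stays open whether the gain comes from gaining methylsulfonyl or from losing 2-cyano-2-methylpropyl. On these data alone, it is also open how a carboxylic acid or an amine would behave at this place, and whether methylsulfonyl keeps its number on a longer chain.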